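The source may report more compounds than this note shows. Statements on the series, on what has been measured and on what is new or still open speak of the compounds shown alone.

In a physicochemical assay for solubility, read by spectrophotometry, at pH 6.8 (on this read-out lower numbers stand for lower solubility and higher numbers for higher solubility), compound 2 `O=c1[nH]c2ccc(Nc3cc(NCc4cccnc4)c([N+](=O)[O-])cc3Cl)cc2[nH]1` gives < 0.23 ug/mL, which is a limit and not a number. Compound 1 `O=C(O)CCNc1cc(Nc2ccc3[nH]c(=O)[nH]c3c2)c(Cl)cc1[N+](=O)[O-]` gives > 72 ug/mL, also a limit. Compound 3 `O=c1[nH]c2ccc(Nc3cc(NC4CCOCC4)c([N+](=O)[O-])cc3Cl)cc2[nH]1` gives 0.61 ug/mL, a true number. Compound 4 `O=c1[nH]c2ccc(Nc3cc(OC4CCOCC4)c([N+](=O)[O-])cc3Cl)cc2[nH]1` differs from compound 2 by having (oxan-4-yl)oxy in place of ((pyridin-3-yl)methyl)amino on an aromatic carbon. The closest guide is an at least 2.6-fold higher number from compound 2 to compound 3 (0.42 log units; beyond the scatter), with oxan-4-yl in place of (pyridin-3-yl)methyl on a nitrogen on an aromatic ring. The large steps of an at least 310-fold lower number from compound 1 to compound 2 (2.49 log units; beyond the scatter) and an at least 110-fold lower number from compound 1 to compound 3 (2.07 log units; beyond the scatter) involve a 2-carboxyethyl group absent from both sides of this change. Among the compounds with values here, no measured step swaps the linking nitrogen for oxygen. A modest rise is therefore expected, estimated as an at least 2.1-fold higher number from compound 2 to compound 4 (0.33 log units; beyond the scatter). For compound 4 the estimate in this assay is 0.5 ug/mL, with an expected range of 0.15 ug/mL to 1.8 ug/mL.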

Compound 4, solubility: 18 ug/mL
The estimate for compound 4 lay 36-fold (1.56 log units) below the measured number, and the stated range ends below it.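

At this position, ortho to a nitro group, the linking atom itself turns out to matter: in this assay oxygen in place of nitrogen, with the oxan-4-yl ring kept, gives a 30-fold higher number from compound 3 to compound 4 (1.47 log units; beyond the scatter) as a step of its own. The full swap gives an at least 78-fold higher number from compound 2 to compound 4 (1.89 log units; beyond the scatter) from a starting value that is a limit and not a number. Even so, (2-carboxyethyl)amino stays ahead, as an at least 4.0-fold lower number from compound 1 to compound 4 (0.60 log units; beyond the scatter) also starts from a limit.

On these data alone, whether oxygen gives a similar rise with other groups stays open, for example with a (pyridin-3-yl)methoxy group or a longer ether chain. The compounds shown also give no reason for the size of this step.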